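This account rests on a few compounds, and the source may have more. Where it says the series, first, only, none or still open, it means among the compounds named here.

Measured compounds:
- compound 1 `COC(=O)C1=C(C)NC(=O)NC1c1cccs1`: 19%
- compound 2 `CC1=C(C(=O)CC(C)C)C(c2cccs2)NC(=O)N1`: 43%

In an assay on membranes from HEK293 cells for displacement of a labelled ligand from adenosine receptor A2b (Homo sapiens), read by scintillation counting, with a stated time of 30 min, tested at 1 uM (on this read-out higher numbers stand for more inhibition at the one concentration tested (going by the name of the read-out) and lower numbers for less inhibition), compound 1 gives 19% and compound 2 gives 43%. Compound 2 stands highest of the two numbers shown; the only measured step is a number 24 percentage points higher from compound 1 to compound 2 (beyond the scatter), a change at the carbonyl carbon attached to the core of compound 1.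

Compound 3 `CCSC(=O)C1=C(C)NC(=O)NC1c1cccs1` has not yet been measured in this assay. It differs from compound 2 by ethylsulfanyl in place of isobutyl on a carbonyl carbon. For the measured compounds named here, the one measured step that bears on it, a number 24 percentage points higher from compound 1 to compound 2 (beyond the scatter), shows that a change at this same carbonyl carbon can move the read-out by a modest amount. The ethylsulfanyl group of compound 3 carries an acceptor, as the methoxy of compound 1 does, while the isobutyl of compound 2 does not. Compound 3 is therefore expected to fall back part of the way toward compound 1, with an expected step of a number 15 percentage points lower from compound 2 to compound 3 (beyond the scatter). The estimate for compound 3 is 28%, with a range from 10% to 48%.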

Compound 3, a percentage reported as inhibition, at one concentration (the size of the read-out at that concentration, not a potency): 1%
The estimate for compound 3 lay 27 percentage points above the measured number; measured number outside the range, below it.
By their numbers in this assay, from the lowest: compound 3; then compound 1; then compound 2.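

In this assay, the change at this carbonyl carbon gives a number 42 percentage points lower from compound 2 to compound 3 (beyond the scatter), and against the methoxy of the shared core it gives a number 18 percentage points lower from compound 1 to compound 3 (beyond the scatter), so this position can lower the read-out as well as raise it. The hydrogen-bond acceptor that ethylsulfanyl brings does not place compound 3 level with compound 1, so acceptor count alone does not sort these three compounds. No measured evidence accounts for either step. 

From the compounds shown here alone, it stays open whether the drop follows the sulfur or the ethyl chain, and an ethoxy group on the same carbonyl carbon would separate the two. Going by these compounds, it also stays open whether an amine or a longer branched chain there would take the read-out beyond that of compound 2.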